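Replacing the aromatic heteroring of compound 1 with oxolanyl

A few compounds are considered here, and "the series" means these few. Any claim that something is new, unique, unknown or untested is made for them only; others in the source may bear on it.

Three compounds of the shared core have numbers in an assay on isolated protein for inhibition of ubiquitin carboxyl-terminal hydrolase 7 (Homo sapiens), with stated times of 30 min and 2 h; on this read-out lower numbers stand for stronger inhibition and higher numbers for weaker inhibition. Compound 1 `Cn1nc2c(=O)n(CC3(O)CCN(Cc4ccc(-c5n[nH]c(=O)o5)cc4Cl)CC3)cnc2c1-c1ccc(CN)cc1` gives 171 nM. Compound 3 `Cn1nc2c(=O)n(CC3(O)CCN(Cc4ccc(-c5ccco5)cc4Cl)CC3)cnc2c1-c1ccc(C2(N)CC2)cc1` gives 66.1 nM, and compound 2 `Cn1nc2c(=O)n(CC3(O)CCN(Cc4ccc(-c5ccco5)cc4Cl)CC3)cnc2c1-c1ccc(CNC(=O)C(F)(F)F)cc1` gives 2060 nM. Compound 1 therefore stands second highest of the three: compound 3 sits below it by more than the scatter, compound 2 well above it.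

Among the measured compounds shown here, the only single-place step measured is a 31-fold lower number from compound 2 to compound 3 (1.49 log units; beyond the scatter), which concerns the substituent on the far aryl ring and not the place changed here. Compounds 2 and 3 differ from compound 1 at two places at once, so their values give no clean reading on the change below.

Compound 4 `Cn1nc2c(=O)n(CC3(O)CCN(Cc4ccc(C5CCCO5)cc4Cl)CC3)cnc2c1-c1ccc(CN)cc1` differs from compound 1 by a group of 5 heavy atoms (4 carbon, 1 oxygen; one five-membered non-aromatic ring with 1 hetero atom) in place of a group of 6 heavy atoms (2 carbon, 2 nitrogen, 2 oxygen; one five-membered aromatic ring with 3 hetero atoms), on an aromatic carbon. For the measured compounds named here, no measured step bears on this exchange. With the donor and two of the acceptors gone and a saturated ring in place of an aromatic one, the expectation is a small weakening, of about a 1.9-fold higher number from compound 1 to compound 4 (0.27 log units; within the scatter), though a result within the scatter cannot be ruled out. Compound 4 is thus estimated at 320 nM in this assay, with a range from 110 nM to 950 nM.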

Compound 4, half-maximal inhibitory concentration: 3820 nM
The estimate for compound 4 lay 12-fold (1.08 log units) below the measured number, outside the stated range (above it).
By their numbers in this assay, from the lowest: compound 3; then compound 1; then compounds 2 and 4 (each within the scatter of the next).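

Among the compounds shown here, this is the first reading at this place that is not confounded by a second change: on the aromatic carbon para to a large group and meta to the chloro group, exchanging the five-membered aromatic ring with 3 hetero atoms for oxolan-2-yl gives a 22-fold higher number from compound 1 to compound 4 (1.35 log units; beyond the scatter) in this assay. The rest of compound 4 matches compound 1, so the whole step belongs to this exchange, and the place is clearly not indifferent to the group it carries. The exchange alters several things at once, including aromatic against non-aromatic ring, the count of hydrogen-bond donors and acceptors, and the double bond outside the ring, and no measurement available here accounts for the size of the step.

Which of these differences carries the step stays open, since a single exchange cannot separate them, and a pair differing only at this place with furan-2-yl against oxolan-2-yl would address the ring's aromatic character directly. Also open, as far as these compounds go, is how a carboxylic acid or a primary carboxamide on the same aromatic carbon would compare with the group of compound 1.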